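Pyrimidine ether to pyrimidine thioether in the aspartyl ketone series

The source may report more compounds than this note shows. Statements on the series, on what has been measured and on what is new or still open speak of the compounds shown alone.

The series shares a naphthyloxyacetyl-valine-aspartyl ketone core and varies the group on the saturated chain carbon bound to the ketone carbonyl. Compound 1 `CC(C)[C@H](NC(=O)COc1cccc2ccccc12)C(=O)N[C@@H](CC(=O)O)C(=O)CSc1nc(-c2ccccc2)cs1` gives in a functional assay on Jurkat cells (Homo sapiens) for inhibition (a higher number here means a weaker inhibitor, a lower number a stronger inhibitor), only a limit, > 200000 nM, and not a number. Compound 2 `CC(C)[C@H](NC(=O)COc1cccc2ccccc12)C(=O)N[C@@H](CC(=O)O)C(=O)CSc1nc(-c2ccccc2)no1` gives 102000 nM in this assay. Compound 3 `Cc1cc(OCC(=O)[C@H](CC(=O)O)NC(=O)[C@@H](NC(=O)COc2cccc3ccccc23)C(C)C)nc(C)n1` returns only a limit, > 200000 nM, so its standing can be read only as sitting at the floor of the measured range (the limit of > 200000 nM in this assay, at which 2 of the 3 values shown sit). The change to compound 4 `Cc1cc(C)nc(SCC(=O)[C@H](CC(=O)O)NC(=O)[C@@H](NC(=O)COc2cccc3ccccc23)C(C)C)n1` is (4,6-dimethylpyrimidin-2-yl)sulfanyl in place of (2,6-dimethylpyrimidin-4-yl)oxy on a saturated chain carbon bound to a carbonyl carbon. Among the measured steps, an at least 1.9-fold lower number from compound 1 to compound 2 (0.29 log units; that floor lies within the scatter) shows that a sulfur-linked heteroaryl can reach a number, while an at least 1.9-fold higher number from compound 2 to compound 3 (0.29 log units; that floor lies within the scatter) moves back to the limit; a step that the two limits leave unreadable from compound 1 to compound 3 is unreadable from its two limits. Both sulfur-linked compounds sit at or near the limit, so no step beyond the scatter is expected for compound 4; the estimate for compound 4 is 150000 nM (range 60000 nM to 400000 nM), meaning an expected step of an at least 1.3-fold lower number from compound 3 to compound 4 (0.12 log units; that floor lies within the scatter).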

Compound 4, half-maximal inhibitory concentration: > 200000 nM
Compound 4: a limit, no number; the forecaster's own chance of this, stated with the estimate: 55%; at least 1.3-fold (0.12 log units) between middle value and limit.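

In this assay compound 4 gives only a limit, > 200000 nM, and not a number, so (4,6-dimethylpyrimidin-2-yl)sulfanyl on this saturated chain carbon bound to a carbonyl carbon yields no reading that separates it from (2,6-dimethylpyrimidin-4-yl)oxy. For the compounds shown here, the steps joining compound 4 to compound 3 and to compound 1 cannot be read, and the one readable step, an at least 1.9-fold higher number from compound 2 to compound 4 (0.29 log units; that floor lies within the scatter), shows that a sulfur link alone does not secure a number, as compound 1 and compound 4 also carry that link. The position now reads mostly as a ceiling of the assay: the limit of > 200000 nM in this assay, at which 3 of the 4 values shown sit.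

Left open is whether the 3-phenyl-1,2,4-oxadiazol-5-yl group would reach a number through an oxygen link as well. Also open, going by these compounds, is whether a pyrimidine carrying an amine in place of its methyl groups would move clear of the limit.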